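Amide aryl swap on the flavonol amide series

This account rests on a few compounds, and the source may have more. Where it says the series, first, only, none or still open, it means among the compounds named here.

Compound 2 `O=C(Nc1cccc(-c2oc3cc(-c4ccc(F)cc4)ccc3c(=O)c2O)c1)c1cnc(Cl)nc1Cl` carries a 2,4-dichloropyrimidin-5-yl on the amide carbonyl carbon. In a functional assay on A549 cells (Homo sapiens) for antiproliferative activity, read by CCK-8 assay, with a stated time of 72 h (a higher number here means a weaker inhibitor, a lower number a stronger inhibitor), compound 2 gives > 100000 nM, which is a limit of the assay and not a number (the limit of > 100000 nM in this assay, at which 1 of the 2 values shown sits). Compound 1 `COc1cc(OC)cc(C(=O)Nc2cccc(-c3oc4cc(-c5ccc(F)cc5)ccc4c(=O)c3O)c2)c1`, with 3,5-dimethoxyphenyl in that place, gives 2390 nM in this assay. Within the data shown here, the one measured step is an at least 41-fold higher number from compound 1 to compound 2 (1.62 log units; beyond the scatter), so compound 2 stands at the weak end of what has been measured so far. Compound 3 `O=C(Nc1cccc(-c2oc3cc(-c4ccc(F)cc4)ccc3c(=O)c2O)c1)c1ccc([N+](=O)[O-])cc1` is the next change: 4-nitrophenyl in place of 2,4-dichloropyrimidin-5-yl on a carbonyl carbon. Among the measured compounds shown here, no measured step covers this exact pair; the step from compound 1 to compound 2 shows that exchanging the aryl group on the carbonyl carbon can move the read-out by a large amount, and the change here goes from a six-membered aromatic ring with 2 hetero atoms back to a six-membered aromatic ring of carbon only. The expected step is an at least 10-fold lower number from compound 2 to compound 3 (1.00 log units; beyond the scatter), toward stronger inhibition. Compound 3 is therefore estimated at 10000 nM, in the range 2000 nM to 60000 nM.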

Compound 3, half-maximal inhibitory concentration: 2440 nM
Beside the measured number, compound 3's estimate is 4.1-fold (0.61 log units) above it, and the stated range covers the measured number.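

In this assay, 4-nitrophenyl on the amide carbonyl carbon restores what 2,4-dichloropyrimidin-5-yl loses, with an at least 40-fold lower number from compound 2 to compound 3 (1.61 log units; beyond the scatter). The value for compound 2 is a limit of the assay and not a number: the limit of > 100000 nM in this assay, at which 1 of the 3 values shown sits. The two aromatic rings of carbon only are not told apart here, with a 1.0-fold higher number from compound 1 to compound 3 (0.01 log units; within the scatter), so among the three compounds the loss goes with 2,4-dichloropyrimidin-5-yl alone, although 3,5-dimethoxyphenyl and 4-nitrophenyl carry different substituents.

The compounds shown do not separate the two ring nitrogens from the two chlorines of 2,4-dichloropyrimidin-5-yl as the source of that loss. Also open, from the compounds shown here alone, is how this position responds to an unsubstituted phenyl, a pyridine ring, or a group that is not aromatic, such as a saturated amine or a longer alkyl chain.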